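The compounds below may be only part of what the source reports. "The series", "measured", "known", "first", "only" and "open" are said of these compounds alone.

Measured compounds:
compound 1 `COc1cccc(-c2nc3ccc(C)cn3c2NC2CCCCC2)c1`, 1220 nM
compound 2 `Cc1ccc2nc(-c3ccncc3)c(NC3CCCCC3)n2c1`, 7200 nM

Among the measured compounds shown here, in an assay on cells for inhibition of Polyunsaturated fatty acid 5-lipoxygenase (Homo sapiens), read by HPLC, with stated times of 15 min and 10 min (on this read-out higher numbers stand for weaker inhibition and lower numbers for stronger inhibition), compound 1 gives 1220 nM, the lowest of the two numbers measured so far. For the measured compounds named here, its nearest neighbour is compound 2, which differs only in having pyridin-4-yl in place of 3-methoxyphenyl on an aromatic carbon; that change gives a 5.9-fold higher number from compound 1 to compound 2 (0.77 log units; beyond the scatter), the only step measured here.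

Compound 3 `Cc1ccc2nc(-c3cccc(Oc4ccccc4)c3)c(NC3CCCCC3)n2c1` keeps the shared core of compound 1 and changes only the group on the oxygen: phenyl in place of methyl on an oxygen on an aromatic ring. Read one bond further out, methoxy becomes phenoxy.

Going by the values given here, no measured step covers this kind of change. Among the compounds with values here, the one step known, from the 3-methoxyphenyl of compound 1 to the pyridin-4-yl of compound 2, alters the whole aromatic ring rather than the group on the oxygen, so it does not say how the number of compound 1 responds when methyl becomes phenyl there. With nothing to point one way or the other, the step from compound 1 to compound 3 is expected to be a 1.2-fold lower number from compound 1 to compound 3 (0.09 log units; within the scatter), within the scatter. Compound 3 is therefore estimated at 1000 nM, with a range from 300 nM to 4000 nM.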

Compound 3, half-maximal inhibitory concentration: 500 nM
Beside the measured number, compound 3's estimate is 2.0-fold (0.30 log units) above it, and the stated range covers the measured number.
By their numbers in this assay, from the lowest: compound 3; then compound 1; then compound 2.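

Swapping methyl for phenyl on the oxygen adds a whole six-membered aromatic ring of carbon only, and in this assay this gives a 2.4-fold lower number from compound 1 to compound 3 (0.39 log units; beyond the scatter), so this position accepts a much larger group and the number still falls. Among the compounds shown here, the only earlier step, a 5.9-fold higher number from compound 1 to compound 2 (0.77 log units; beyond the scatter), replaced the entire aromatic ring and moved the number the other way, whereas this step leaves that ring in place and changes only the group on its oxygen, showing for the first time that the number can be lowered from this part of compound 1. No measurement offered here explains why phenoxy gives a lower number than methoxy.

With a single replacement on this oxygen, it remains unclear whether the new aromatic ring matters or whether any larger group would do, and ethoxy or benzyloxy in the place of phenoxy would begin to separate those two readings. It also remains unclear how the number would respond to a chlorine atom or a carboxylic acid on the new phenyl ring.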